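The source may report more compounds than this note shows. Statements on the series, on what has been measured and on what is new or still open speak of the compounds shown alone.

Compound 1 `Cc1ccc(-c2cs/c(=N/NC(=O)CSc3nnnn3-c3ccccc3)n2-c2ccccc2)cc1`: 29.5%
Compound 2 `Cc1ccc(-c2cs/c(=N/NC(=O)CSc3nnc(C)s3)n2-c2ccccc2)cc1`: 40.6%

In a functional assay on C6 cells (Rattus norvegicus) for cytotoxicity, read by MTT assay, with a stated time of 24 h, tested at 50 ug/mL (on this read-out higher numbers stand for a weaker effect at the one concentration tested and lower numbers for a stronger effect), compound 1 gives the lower of the two numbers shown, and the step of a number 11.1 percentage points higher from compound 1 to compound 2 (beyond the scatter) separates the pair. Compound 3 `N#Cc1ccc(-c2cs/c(=N/NC(=O)CSc3nnnn3-c3ccccc3)n2-c2ccccc2)cc1` has not yet been measured. It differs from compound 1 in one place: cyano in place of methyl on an aromatic carbon. Within the data shown here, the only measured step exchanges the group on the sulfur and so touches a different part of the molecule; its size says nothing about how an exchange on the six-membered ring of carbon only might act. Without a comparable step, the expectation rests on compound 1 alone. For compound 3 in this assay no shift beyond the scatter is expected, a number 2.5 percentage points higher from compound 1 to compound 3 (within the scatter). Compound 3 is therefore estimated at 32%, within a range from 15% to 52%, a wide band that reflects the absence of any guiding measurement.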

Compound 3, a percentage reported as activity, at one concentration (the size of the read-out at that concentration, not a potency): 61.1%
Estimate against measurement, compound 3: 29.1 percentage points below; measured number above the stated range.
By their numbers in this assay, from the lowest: compound 1; then compound 2; then compound 3.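

In this assay, cyano in place of methyl on the aromatic ring gives a number 31.6 percentage points higher from compound 1 to compound 3 (beyond the scatter), which means a clearly weaker effect at the one concentration tested. Among these compounds, until now only the group on the sulfur had been varied, so this is the first sign that the 4-methylphenyl part also matters and that exchanging one small group there can cost much of the effect. No measurement at hand explains the shift.

With only methyl and cyano shown at this position, it remains open whether a chlorine atom, a methoxy group or an amine would keep the stronger effect of compound 1 or lose it as cyano does. On these data alone, it is also open whether the same exchange would act alike with the 5-methyl-1,3,4-thiadiazol-2-yl group of compound 2 on the sulfur.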